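Replacing the Ester Side Chain with a Hydroxypropyl Group

The source may report more compounds than this note shows. Statements on the series, on what has been measured and on what is new or still open speak of the compounds shown alone.

Compound 1 `CCOC(=O)C[C@H]1CN(C)CC[C@@H]1c1ccc(Cl)cc1` gives 79 nM in an assay on striatum with sodium-dependent dopamine transporter (Rattus norvegicus) as the target; on this read-out lower numbers stand for stronger inhibition and higher numbers for weaker inhibition.
Compound 2 `CN1CC[C@H](c2ccc(Cl)cc2)[C@@H](CCC(=O)O)C1` gives 1300 nM in this assay.
Compound 3 `COC(=O)/C=C/[C@H]1CN(C)CC[C@@H]1c1ccc(Cl)cc1` gives 53 nM in this assay.

Compound 3 carries the lowest number of the three; compound 1 lies close, a 1.5-fold lower number from compound 1 to compound 3 (0.17 log units; within the scatter), whereas compound 2 sits far away, a 25-fold lower number from compound 2 to compound 3 (1.39 log units; beyond the scatter). Compound 4 `CN1CC[C@H](c2ccc(Cl)cc2)[C@@H](CCCO)C1` differs from compound 3 in one place: 3-hydroxypropyl in place of 2-(methoxycarbonyl)ethenyl on a saturated ring carbon. For the measured compounds named here, two measured steps bear on this change. Both a 16-fold higher number from compound 1 to compound 2 (1.22 log units; beyond the scatter) and a 25-fold lower number from compound 2 to compound 3 (1.39 log units; beyond the scatter) show that exchanging an ester-bearing chain for a carboxylic-acid chain raises the number strongly, while a 1.5-fold lower number from compound 1 to compound 3 (0.17 log units; within the scatter) shows that two ester chains are interchangeable. A hydroxypropyl chain is neither an ester nor an acid, so a rise in this assay of moderate size is expected, smaller than the acid steps. Compound 4 is therefore estimated at 250 nM, between 60 nM and 1000 nM, an expected step of a 4.7-fold higher number from compound 3 to compound 4 (0.67 log units; beyond the scatter).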

Compound 4, inhibition constant: 16 nM
The estimate for compound 4 lay 16-fold (1.19 log units) above the measured number, outside the stated range (below it).
By their numbers in this assay, from the lowest: compound 4; then compounds 3 and 1 (each within the scatter of the next); then compound 2.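

In this assay an ester is not needed at this position: with 3-hydroxypropyl the number falls below both ester chains, by a 3.3-fold lower number from compound 3 to compound 4 (0.52 log units; beyond the scatter) and by a 4.9-fold lower number from compound 1 to compound 4 (0.69 log units; beyond the scatter) in the two comparisons. The carboxylic acid stands apart, as hydroxymethyl in place of carboxy gives an 81-fold lower number from compound 2 to compound 4 (1.91 log units; beyond the scatter) on the same chain length. No measured evidence accounts for this gain.

From the compounds shown here alone, whether the terminal hydroxyl itself counts remains open, a question for a plain propyl chain, a methyl ether or an amine in its place. Going by these compounds, the role of chain length also remains open, and a longer chain ending in hydroxyl would address it.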